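The compounds below may be only part of what the source reports. "The series", "measured", "known", "first", "only" and "open" are said of these compounds alone.

In a functional assay on HepG2 cells (Homo sapiens) for cytotoxicity, read by MTT assay, with a stated time of 48 h (on this read-out lower numbers stand for stronger inhibition and higher numbers for weaker inhibition), compound 1 `C#CCSc1nnc(CC)n1N1C(=O)c2ccccc2C1=O` gives only a limit of the assay, > 200000 nM. Compound 2 `C=CCSc1nnc(CC)n1N1C(=O)c2ccccc2C1=O` likewise sits at a limit, > 200000 nM. Compound 3 `CCc1nnc(SCC(=O)c2ccccc2)n1N1C(=O)c2ccccc2C1=O` also stands at a limit, > 200000 nM, so no number places it relative to the other two. All three rest at the same boundary, (the limit of > 200000 nM in this assay, at which 3 of the 3 values shown sit). The steps a step that the two limits leave unreadable from compound 1 to compound 2, a step that the two limits leave unreadable from compound 1 to compound 3 and a step that the two limits leave unreadable from compound 2 to compound 3 are accordingly unreadable in size and direction. Compound 4 `COc1cc(-c2nnc(SCC(=O)c3ccccc3)n2N2C(=O)c3ccccc3C2=O)cc(OC)c1OC` differs from compound 3 by 3,4,5-trimethoxyphenyl in place of ethyl on an aromatic carbon. Among the measured compounds shown here, none of the measured steps bears on this change, and the unreadable steps supply no size to carry forward. Compound 4 is therefore expected near 120000 nM, within 30000 nM to 400000 nM, and the step of an at least 1.6-fold lower number from compound 3 to compound 4 (0.22 log units; that floor lies within the scatter) is expected to remain of uncertain size.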

Compound 4, half-maximal inhibitory concentration: 171000 nM
Compound 4: middle estimate off by 1.4-fold (0.15 log units), on the low side, within the range that was stated.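

Among the compounds shown here, on this aromatic carbon, 3,4,5-trimethoxyphenyl in place of ethyl gives the first reading in this assay that is a number and not a limit. The change reads as an at least 1.1-fold lower number from compound 3 to compound 4 (0.06 log units; that floor lies within the scatter) and gives only a floor, not a full size. The other compounds all stay at one boundary: the limit of > 200000 nM in this assay, at which 3 of the 4 values shown sit.

From the compounds shown here alone, it remains open whether phenyl without methoxy groups or an amine on this carbon would also give a number. Also open, going by these compounds, is whether vinyl or ethynyl in place of benzoyl would shift the reading with 3,4,5-trimethoxyphenyl present.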